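The source may hold more compounds than are shown below. What is called first, only, known or untested is meant among the compounds shown, and "the series" means these compounds.

Compound 1 `CS(=O)(=O)c1ccc(-c2cnc3[nH]cc(-c4nnc(-c5ccc(F)cc5)o4)c(=O)c3c2)cc1`: 10.7%
Compound 2 `Cc1ccc(-c2nnc(-c3c[nH]c4ncc(-c5ccc(S(C)(=O)=O)cc5)cc4c3=O)o2)cc1`: 7.47%
Compound 3 `CS(=O)(=O)c1ccc(-c2cnc3[nH]cc(-c4nnc(-c5cccnc5)o4)c(=O)c3c2)cc1`: 4.32%

All three numbers come from a functional assay on HCT-116 cells (Homo sapiens) for inhibition, read by MTT assay, with a stated time of 24 h, tested at 2.5 uM; on this read-out higher numbers stand for more inhibition of growth at the one concentration tested and lower numbers for less inhibition of growth. Compound 3 holds the lowest of them, but the gaps to it, a number 6.4 percentage points lower from compound 1 to compound 3 (within the scatter) and a number 3.2 percentage points lower from compound 2 to compound 3 (within the scatter), both fall within the scatter, so the three compounds cannot be told apart.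

Compound 4 `Cc1cccc(-c2nnc(-c3c[nH]c4ncc(-c5ccc(S(C)(=O)=O)cc5)cc4c3=O)o2)c1` differs from compound 3 in one place: 3-methylphenyl in place of pyridin-3-yl on an aromatic carbon. The step that bears most directly on this is a number 3.2 percentage points lower from compound 2 to compound 3 (within the scatter), which swapped a methylphenyl for the pyridin-3-yl and stayed within the scatter; a number 6.4 percentage points lower from compound 1 to compound 3 (within the scatter), a related swap, was also within the scatter. Going back to a methylphenyl in compound 4 is therefore expected to give a number 3.7 percentage points higher from compound 3 to compound 4 (within the scatter), no movement beyond the scatter. Compound 4 is estimated at 8%, with a range from 1% to 17%.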

Compound 4, percent growth inhibition at one concentration: 8.13%
Compound 4: middle estimate off by 0.1 percentage points, on the low side, within the range that was stated.
By their numbers in this assay, from the lowest: compounds 3, 2, 4 and 1 (each within the scatter of the next).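

In this assay the 3-methylphenyl group adds a new placing of the methyl on the phenyl ring, and this changes nothing that can be told apart (the three steps: a number 0.7 percentage points higher from compound 2 to compound 4 (within the scatter) and a number 3.8 percentage points higher from compound 3 to compound 4 (within the scatter) and a number 2.6 percentage points lower from compound 1 to compound 4 (within the scatter)). All four groups at this position on the five-membered ring therefore remain indistinguishable at the one concentration tested. Nothing here gives a reason for this result. Still open, going by these compounds, is whether an amine or a carboxylic acid on this phenyl ring would move the number beyond the scatter.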